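The compounds below may be only part of what the source reports. "The series", "measured", "known", "first", "only" and "open" are said of these compounds alone.

Measured so far:
Compound 1 `CCn1c(C(=O)NCCCN(C)C)ccc1C(CC)(CC)c1ccc(OCCC(O)(CC)CC)c(C)c1`: 3350 nM
Compound 2 `CCN(CC)CCNC(=O)c1ccc(C(CC)(CC)c2ccc(OCCC(O)(CC)CC)c(C)c2)n1CC`: 550 nM
Compound 3 `CCn1c(C(=O)NCC#N)ccc1C(CC)(CC)c1ccc(OCCC(O)(CC)CC)c(C)c1`: > 50000 nM, a limit of the assay and not a number

In a functional assay on MCF7 cells (Homo sapiens) for antiproliferative activity, read by MTT assay, with a stated time of 48 h (a lower number here means a stronger inhibitor, a higher number a weaker inhibitor), compound 2 gives the lowest number in the set, 550 nM. Going by the values given here, the only other true number belongs to compound 1, and the gap between them lies beyond the usual scatter.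

Compound 4 `CCn1c(C(=O)NCCN)ccc1C(CC)(CC)c1ccc(OCCC(O)(CC)CC)c(C)c1` has not yet been measured. It keeps the core of compound 2 and carries amino in place of diethylamino on a saturated chain carbon, two bonds along the chain from an amide-type nitrogen.

Among the compounds with values here, two measured steps bear on this change. The first is modest: a 6.1-fold lower number from compound 1 to compound 2 (0.78 log units; beyond the scatter). It shows that altering the amine end of the chain can move the number beyond the scatter. The second is large: an at least 90-fold higher number from compound 2 to compound 3 (1.95 log units; beyond the scatter). Here the whole amine end gives way to cyano. Compound 4 keeps an amino group where compound 3 has none, so its step should resemble the modest one more than the large one. With so few compounds, this expectation is loose.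

The expected change in this assay is a 6.4-fold higher number from compound 2 to compound 4 (0.80 log units; beyond the scatter), towards a higher number. For compound 4 the estimated value is 3500 nM, with an expected range of 1000 nM to 15000 nM.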

Compound 4, half-maximal inhibitory concentration: 670 nM
Beside the measured number, compound 4's estimate is 5.2-fold (0.72 log units) above it, and the stated range ends above it.
By their numbers in this assay, from the lowest: compounds 2 and 4 (each within the scatter of the next); then compound 1. At a limit, above all of these: compound 3.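

Shortening diethylamino to amino, on a saturated chain carbon two bonds along the chain from an amide-type nitrogen, gives little change in this assay (a 1.2-fold higher number from compound 2 to compound 4 (0.09 log units; within the scatter)), so the ethyl groups on that nitrogen are not needed to keep the number low. Compound 4 also stands clear of compound 1 (a 5.0-fold lower number from compound 1 to compound 4 (0.70 log units; beyond the scatter)), which shows that a bare amino group does not by itself bring a loss, although this step changes both the chain and the groups on its nitrogen. Aminomethyl in place of cyano gives a far larger difference (an at least 74-fold lower number from compound 3 to compound 4 (1.87 log units; beyond the scatter)), and so, among these compounds, the clear divide at the chain end runs between the amine-bearing compounds and the nitrile.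

On these data alone, it remains open how a methylamino group, a carboxylic acid or a longer chain ending in amino would behave at this end, and whether the number for compound 1 follows from its chain or from its dimethylamino group. Compound 3 holds only a limit of the assay and not a number, which leaves the true size of its steps unknown: the limit of > 50000 nM in this assay, at which 1 of the 4 values shown sits.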